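Aortic maximal response across a prenylated chalcone and flavanone pair

The source may report more compounds than this note shows. Statements on the series, on what has been measured and on what is new or still open speak of the compounds shown alone.

Measured so far:
compound 1 `CC(C)=CCc1c(O)cc(O)c(C(=O)/C=C/c2ccc(Cl)cc2)c1O`: 64.4%
compound 2 `CC(C)=CCc1c(O)cc(O)c2c1OC(c1cccc(Br)c1)CC2=O`: 78.2%

In a functional assay on aorta (Rattus norvegicus, strain Sprague-Dawley) (a lower number here means a smaller maximal response, a higher number a larger maximal response), compound 2 gives 78.2%, the higher of the two numbers at hand. Compound 1 gives 64.4% in this assay, a gap that falls beyond the scatter of repeat measurements, so compound 2 stands at the top of this short series. Among the measured compounds shown here, no pair of measured compounds differs in a single place, so no isolated step is available to calibrate the next change.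

Compound 3 `COc1cc(C2CC(=O)c3c(O)cc(O)c(CC=C(C)C)c3O2)ccc1O` departs from compound 2 by 4-hydroxy-3-methoxyphenyl in place of 3-bromophenyl on a saturated ring carbon.

Nothing in the two measured values bears directly on this change, so the expected step of a number 8.2 percentage points lower from compound 2 to compound 3 (within the scatter) is taken as small, at or near the scatter, with no firm direction. For compound 3 the expected result in this assay is 70%, within 50% to 90%.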

Compound 3, largest response reached (Emax), in percent of the reference or control that the assay uses: 95.8%
For compound 3 the middle estimate is 25.8 percentage points below the measured one; measured number outside the range, above it.
By their numbers in this assay, from the lowest: compound 1; then compound 2; then compound 3.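

In this assay, 4-hydroxy-3-methoxyphenyl in place of 3-bromophenyl on the saturated ring carbon next to the ring oxygen gives a number 17.6 percentage points higher from compound 2 to compound 3 (beyond the scatter). Among the compounds shown here, this is the first single-place step, and it shows that the response changes with the aryl group at this position while the rest of the shared core stays the same. The entering group brings one hydrogen-bond donor and two hydrogen-bond acceptors where the leaving group has none, but nothing at hand accounts for the step.

The compounds shown leave open whether the hydroxy group, the methoxy group or the loss of bromine carries the step. Also open, as far as these compounds go, is how a dimethylamino group or a carboxylic acid on this phenyl ring would read in this assay.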